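Swapping the Acid-Bearing Amide for a Small Alkoxyamide

This account rests on a few compounds, and the source may have more. Where it says the series, first, only, none or still open, it means among the compounds named here.

For the measured compounds named here, compound 3 `CC(C)=CCCC1=CC[C@@H](C(=O)Nc2ccc(C(=O)O)cc2)[C@H](c2ccccc2)C1` gives 2200 nM in an assay on isolated protein for inhibition of Apoptosis regulator Bcl-2 (Homo sapiens), read by fluorescence polarization, with stated times of 5 min and 10 min (on this read-out higher numbers stand for weaker inhibition and lower numbers for stronger inhibition), and is the only compound here with a measured number. Compound 2 `CC(C)=CCCC1=CC[C@@H](C(=O)N(C)C)[C@H](c2ccccc2)C1` reports only a limit of the assay, > 23000 nM. Compound 1 `CON(C)C(=O)[C@H]1CC2=C(CCCC2(C)C)C[C@@H]1c1ccccc1`, which carries a methoxy(methyl)amino amide on a different core, likewise reports only a limit, > 23000 nM. Compound 4 `CON(C)C(=O)[C@@H]1CC=C(CCC=C(C)C)C[C@H]1c1ccccc1` differs from compound 3 by methoxy(methyl)amino in place of (4-carboxyphenyl)amino on a carbonyl carbon. Going by the values given here, the one measured step that bears on this change is an at least 10-fold lower number from compound 2 to compound 3 (1.01 log units; beyond the scatter), and compound 4 runs that step backwards toward the small amide; compound 1 also sits at the limit of > 23000 nM in this assay, at which 2 of the 3 values shown sit. Compound 4 is therefore expected to lose potency in this assay by about a 14-fold higher number from compound 3 to compound 4 (1.13 log units; beyond the scatter), most likely back to the limit. The estimate for compound 4 is 30000 nM, within 8000 nM to 120000 nM.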

Compound 4, inhibition constant: > 23000 nM
Compound 4: no number, only a limit; the forecaster's own chance of this, stated with the estimate: 85%; the middle value is on the limit's open side.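

Placing methoxy(methyl)amino on the carbonyl carbon in place of (4-carboxyphenyl)amino gives, in this assay, an at least 10-fold higher number from compound 3 to compound 4 (1.01 log units; beyond the scatter). The reading for compound 4 is a limit, not a number, and the step from compound 2 to compound 4 cannot be read. With compound 4, a second small amide on the shared core joins compound 2 at that limit, leaving compound 3 the only one with a number: the limit of > 23000 nM in this assay, at which 3 of the 4 values shown sit.

Still open, from the compounds shown here alone, is which part of (4-carboxyphenyl)amino carries the difference. A plain phenylamino amide or a methyl ester of the carboxylic acid would separate the aromatic ring from the acid.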